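The source may hold more compounds than are shown below. What is called first, only, known or untested is meant among the compounds shown, and "the series" means these compounds.

Measured so far in an ADME assay on Vero cells (Chlorocebus sabaeus) for cytotoxicity, read by neutral red uptake, tested at 98 ug/mL; a lower number here means a stronger effect, a higher number a weaker effect of the compound at the concentration tested:
- compound 2, `O=C1CSC(c2cccc(O)c2)N1CCN1CCCCC1`, gives 100%
- compound 3, `COc1ccccc1C1SCC(=O)N1CCN1CCCCC1`, gives 100%
- compound 1, `O=C1CSC(c2c(Cl)cccc2Cl)N1CCN1CCCCC1`, gives 76%

Compound 2 stands level with compound 3 in this assay, the two within the scatter of each other and together the highest of the three numbers; compound 1 lies a step lower, beyond the scatter. Compound 4, `O=C1CSC(c2ccc(F)cc2)N1CCN1CCCCC1`, has not yet been measured. It differs from compound 2 in one place: 4-fluorophenyl in place of 3-hydroxyphenyl on a saturated ring carbon. Among the compounds with values here, no single-change step between measured compounds is available to guide the size of this change. Because compound 2 gives 100% and compound 3 gives 100%, the expected step of a number 5 percentage points lower from compound 2 to compound 4 (within the scatter) is small, downward if anything, and likely not beyond the scatter. Compound 4 is therefore expected to give about 95% in this assay, in the range 80% to 100%.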

Compound 4, a percentage reported as activity, at one concentration (the size of the read-out at that concentration, not a potency): 87%
Estimate against measurement, compound 4: 8 percentage points above; the range from low to high includes it.
By their numbers in this assay, from the lowest: compound 1; then compound 4; then compounds 2 and 3 (each within the scatter of the next).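

Going from 3-hydroxyphenyl to 4-fluorophenyl on the saturated ring carbon gives, in this assay, a number 13 percentage points lower from compound 2 to compound 4 (beyond the scatter) and so provides the first single-change step at this position, showing that the read-out responds to the aryl group placed there. The change swaps the hydroxyl for fluorine and also alters where the substituent sits on the phenyl ring, and this one step cannot separate the two. No measurement at hand bears on the origin of the step.

The compounds shown leave open which of the two changes matters. Neither 3-fluorophenyl nor 4-hydroxyphenyl is among them, and neither is an aryl group carrying an amine.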